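This account rests on a few compounds, and the source may have more. Where it says the series, first, only, none or still open, it means among the compounds named here.

Three compounds have so far been measured in a functional assay on BXPC-3 cells (Homo sapiens) for inhibition, read by MTT assay, with a stated time of 72 h; on this read-out higher numbers stand for weaker inhibition of growth and lower numbers for stronger inhibition of growth:

Compound 1 `O=S(=O)(NCCNCc1cccc2ccccc12)c1cc(C(F)(F)F)cc(C(F)(F)F)c1` gives 23000 nM.
Compound 2 `O=S(=O)(NCCCNCc1ccccc1Cl)c1cc(C(F)(F)F)cc(C(F)(F)F)c1` gives 11000 nM.
Compound 3 `O=S(=O)(NCCNCc1ccc(-c2ccccc2)cc1)c1cc(C(F)(F)F)cc(C(F)(F)F)c1` gives 1600 nM.

Compound 2 stands second highest of these three numbers. Compound 1 gives a higher number than compound 2, a gap beyond the scatter, and compound 3 gives a lower number than compound 2, a gap also beyond the scatter. No pair of these compounds differs in only one place, so no single step has been measured.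

Compound 4 `O=S(=O)(NCCCNCc1ccc(Cl)c(Cl)c1)c1cc(C(F)(F)F)cc(C(F)(F)F)c1` is the next compound. It differs from compound 2 by 3,4-dichlorophenyl in place of 2-chlorophenyl on a saturated chain carbon bound to an amine nitrogen. Going by the values given here, nothing among the measured compounds shows this kind of change, so only a small shift is expected, within or just beyond the scatter, most likely toward a somewhat lower number. Compound 4 is expected to give about 8000 nM, with a range from 3000 nM to 20000 nM. That estimate means a step of a 1.4-fold lower number from compound 2 to compound 4 (0.14 log units; within the scatter) in this assay.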

Compound 4, concentration for 50% growth inhibition: 1400 nM
Beside the measured number, compound 4's estimate is 5.7-fold (0.76 log units) above it, and the stated range ends above it.
By their numbers in this assay, from the lowest: compounds 4 and 3 (each within the scatter of the next); then compound 2; then compound 1.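

In this assay, going by these compounds alone, this is the first single change that can be read, and it shows that the ring on a saturated chain carbon bound to an amine nitrogen is not indifferent to its chlorines: 3,4-dichlorophenyl in place of 2-chlorophenyl gives a 7.9-fold lower number from compound 2 to compound 4 (0.90 log units; beyond the scatter). Nothing available here explains the size of this step.

This change alters both the number and the placement of the chlorines, so the two effects cannot be separated. Going by these compounds, how a plain phenyl, or a methoxy or nitrile in place of chlorine, would compare remains open.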